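This account rests on a few compounds, and the source may have more. Where it says the series, first, only, none or still open, it means among the compounds named here.

Among the measured compounds shown here, in a functional assay on KB cells (Homo sapiens) for inhibition, with a stated time of 72 h (a higher number here means a weaker inhibitor, a lower number a stronger inhibitor), compound 1 `COc1ccc(S(=O)(=O)N2CCc3cccc(-c4ccc(F)c(F)c4)c32)cc1` gives 45 nM, the lowest of the two numbers so far. Compound 2 `COc1ccc(S(=O)(=O)N2CCc3cccc(-c4cc(OC)c(OC)c(OC)c4)c32)cc1` gives 3690 nM, a much higher number that marks a far weaker inhibitor. Compound 3 `COc1ccc(S(=O)(=O)N2CCc3cccc(-c4ccncc4)c32)cc1` has pyridin-4-yl in place of 3,4-difluorophenyl on an aromatic carbon. For the measured compounds named here, no measured pair isolates this change, so any forecast is rough. A moderate upward move is expected, a 3.3-fold higher number from compound 1 to compound 3 (0.52 log units; beyond the scatter), which would make compound 3 a somewhat weaker inhibitor. Compound 3 is estimated at 150 nM, with an expected range of 40 nM to 600 nM.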

Compound 3, half-maximal inhibitory concentration: 96 nM
Estimate against measurement, compound 3: 1.6-fold (0.19 log units) above; the measured number falls inside the stated range.
By their numbers in this assay, from the lowest: compound 1; then compound 3; then compound 2.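

In this assay, the step is modest, a 2.1-fold higher number from compound 1 to compound 3 (0.33 log units; beyond the scatter), so this position accepts a ring holding a nitrogen and no fluorine at only a small cost. Compound 3 at 96 nM also stays far below compound 2 at 3690 nM, so the new ring keeps most of the inhibition. Nothing available explains the step. As far as these compounds go, the swap adds a ring nitrogen and removes both fluorines at once, so which of these drives the step remains open. A plain phenyl ring or pyridin-3-yl at this place would help separate the two.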